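The source may hold more compounds than are shown below. What is called first, only, known or untested is meant among the compounds shown, and "the series" means these compounds.

Measured in a physicochemical assay for metabolic stability, read by HPLC, in phosphate buffer, at pH 7.4, tested at 10 uM; on this read-out lower numbers stand for a shorter-lived compound and higher numbers for a longer-lived compound:
- Compound 1 `CCCCCCNC(=O)n1cnc2ccccc21`: 0.983 h
- Compound 2 `Cc1ccc(CNC(=O)n2c(N)nc3ccccc32)cc1`: 0.383 h
- Compound 3 `Cc1nc2ccccc2n1C(=O)NCCCCc1ccccc1`: 0.117 h

Compound 2, at 0.383 h, holds the middle place of the three. Compound 1 lies higher and compound 3 lies lower, both beyond the scatter. Compound 4 `Nc1nc2ccccc2n1C(=O)NCc1ccccc1` differs from compound 2 in one place: hydrogen in place of methyl on an aromatic carbon. Going by the values given here, no two measured compounds differ in only one place, so no measured step shows the size of this change. A step within the scatter is expected, with no clear direction in this assay. The expected step is a 1.1-fold lower number from compound 2 to compound 4 (0.03 log units; within the scatter). For compound 4 the estimate is 0.36 h, with an expected range from 0.2 h to 0.65 h.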

Compound 4, half-life: 0.217 h
Estimate against measurement, compound 4: 1.7-fold (0.22 log units) above; the measured number falls inside the stated range.
By their numbers in this assay, from the lowest: compounds 3, 4 and 2 (each within the scatter of the next, the first and the last beyond it); then compound 1.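

In this assay, going by these compounds alone, the change from 4-methylphenyl to phenyl gives a 1.8-fold lower number from compound 2 to compound 4 (0.25 log units; within the scatter) and is the first step measured at this position. On this aromatic carbon, para to a large group, hydrogen can thus stand in place of methyl without a step beyond the scatter. Nothing available gives a reason for the size of this step.

From the compounds shown here alone, whether a methoxy group, a chlorine atom or a longer chain at this position would give a larger step remains open. So does whether the same change would give a similar step on the cores of compound 1 or compound 3.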